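The source may report more compounds than this note shows. Statements on the series, on what has been measured and on what is new or still open speak of the compounds shown alone.

Working notes on the sulfonamide series.

Compound 1 `O=S(=O)(Nc1ccc(Cl)c(Cl)c1)c1ccc(-c2cnc(C3CC3)o2)cc1` stands in a functional assay on cells (leukaemia cell line, Homo sapiens) for inhibition, read by sulforhodamine B assay, with a stated time of 48 h (a higher number here means that more compound is tolerated, a lower number that less compound is tolerated), only as a limit: compound 1 gives > 100000 nM, which is the limit of the assay and not a number. Compound 2 `O=S(=O)(Nc1cc(Cl)ccc1Cl)c1ccc(-c2cnc(C3CC3)o2)cc1` is also returned as a limit in this assay, where compound 2 gives > 100000 nM. Compound 3 `Cc1cc(Cl)ccc1NS(=O)(=O)c1ccc(-c2cnc(C3CC3)o2)cc1` gives > 100000 nM in this assay, again a limit and not a number.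

The three steps among the measured compounds, all on the sulfonamide nitrogen, are therefore not readable: a step that the two limits leave unreadable from compound 1 to compound 2, a step that the two limits leave unreadable from compound 1 to compound 3 and a step that the two limits leave unreadable from compound 2 to compound 3 cannot be sized because of the limit of > 100000 nM in this assay, at which 3 of the 3 values shown sit.

Compound 4 `Cc1cc(Cl)cc(NS(=O)(=O)c2ccc(-c3cnc(C4CC4)o3)cc2)c1` is the next variation at the same position: 3-chloro-5-methylphenyl in place of 3,4-dichlorophenyl on a sulfonamide nitrogen. Among the measured compounds shown here, no measured step gives a direction or size for this change, since every aryl group tried so far on the sulfonamide nitrogen returned the limit in this assay. Compound 4 is expected to behave the same way, with the step from compound 1 expected as a step that the limit leaves unreadable from compound 1 to compound 4, most likely reported again only as a limit. The estimate for compound 4 in this assay is 200000 nM, with a range from 50000 nM to 1000000 nM.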

Compound 4, concentration lethal to 50% of the cells: 84900 nM
Beside the measured number, compound 4's estimate is 2.4-fold (0.37 log units) above it, within the range that was stated.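

In this assay, among the compounds shown here, compound 4 gives 84900 nM, the first number at this position rather than a limit, so the sulfonamide nitrogen can carry an aryl group that returns a readable value. Set against the three earlier aryl groups, the 3-chloro-5-methylphenyl group gives an at least 1.1-fold lower number from compound 1 to compound 4 (0.07 log units; that floor lies within the scatter), an at least 1.1-fold lower number from compound 3 to compound 4 (0.07 log units; that floor lies within the scatter) and an at least 1.1-fold lower number from compound 2 to compound 4 (0.07 log units; that floor lies within the scatter); each of these is only a floor, so the data do not yet establish a real difference from any of the earlier compounds. The true size of these steps stays unknown, and the steps among compound 1, compound 2 and compound 3 cannot be read at all, because each comparison rests on a limit: the limit of > 100000 nM in this assay, at which 3 of the 4 values shown sit.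

Which of the chlorine and the methyl of the 3-chloro-5-methylphenyl group goes with the number for compound 4 stays open. Also open, from the compounds shown here alone, is how the value at this position would respond to an aryl group carrying an amine or a carboxylic acid, or to a longer chain in place of the methyl.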